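One Aryl Swap and Its Expected Effect on Cell Toxicity

The compounds below may be only part of what the source reports. "The series", "measured", "known", "first", "only" and "open" are said of these compounds alone.

Three compounds share one core. Compound 1 (`C[C@]1(CN2CCc3oc(-c4ccc(F)c(F)c4)nc3C2)Cn2cc([N+](=O)[O-])nc2O1`) was not run in the toxicity test: in an ADME assay on Vero cells (Chlorocebus sabaeus) for cytotoxicity, read by MTT assay, with a stated time of 72 h (on this read-out higher numbers stand for lower toxicity in this test and lower numbers for higher toxicity in this test), compound 1 shows "not determined" (no result reported). Compound 2 (`C[C@]1(CN2CCc3nc(-c4ccc(C(F)(F)F)cc4)ccc3C2)Cn2cc([N+](=O)[O-])nc2O1`) carries a 4-(trifluoromethyl)phenyl group. In this assay compound 2 reaches > 32 ug/mL, which is a limit of the test rather than a number. On the numbers shown, compound 2 therefore stands at the limit of > 32 ug/mL in this assay, at which 1 of the 2 values shown sits, the only value among the two entries. Within the data shown here, no two measured compounds differ in one place, so no measured step exists to lean on. Compound 3 (`C[C@]1(CN2CCc3nc(-c4ccc(F)c(Cl)c4)ccc3C2)Cn2cc([N+](=O)[O-])nc2O1`) is the one still to be measured; the change is 3-chloro-4-fluorophenyl in place of 4-(trifluoromethyl)phenyl on an aromatic carbon. The step that the limit leaves unreadable from compound 2 to compound 3 in this assay is expected to be none beyond the scatter, since compound 2 gave only a limit (the limit of > 32 ug/mL in this assay, at which 1 of the 2 values shown sits). Compound 3 is estimated at 40 ug/mL, within 16 ug/mL to 100 ug/mL, most likely again reported only as the limit.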

Compound 3, half-maximal cytotoxic concentration: > 32 ug/mL
Compound 3 ended at the assay's limit; the forecaster's own chance of this, stated with the estimate: 75%; the middle value is on the limit's open side.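

Compound 2 and compound 3 both end at a limit of this assay rather than at a number, so no step between them can be read: the limit of > 32 ug/mL in this assay, at which 2 of the 3 values shown sit.

The compounds shown leave open whether 3-chloro-4-fluorophenyl in place of 4-(trifluoromethyl)phenyl changes cell toxicity at all, since neither compound has an exact value.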